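The source may report more compounds than this note shows. Statements on the series, on what has been measured and on what is new or still open speak of the compounds shown alone.

Measured so far:
compound 1, `Cn1c(COc2cccc(C(=O)O)c2)nc2ccc(Oc3ccccn3)cc21`, gives 0.4 in a physicochemical assay for lipophilicity, read by LC-MS, in phosphate buffer, measured as octanol-water partition, with a stated time of 30 min, at pH 7.4, tested at 200 mM; on this read-out higher numbers stand for higher lipophilicity and lower numbers for lower lipophilicity
compound 2, `Cc1ccc(Oc2ccc3nc(COc4cccc(C(=O)O)c4)n(C)c3c2)nc1`, gives 0.9

Among the compounds with values here, compound 2 stands highest of the two numbers in this assay, with compound 1 as its only neighbour. Within the data shown here, the single measured step, a number 0.50 log units higher from compound 1 to compound 2 (beyond the scatter), is a modest rise that lies beyond the scatter.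

Compound 3, `Cc1ccnc(Oc2ccc3nc(COc4cccc(C(=O)O)c4)n(C)c3c2)c1`, differs from compound 2 by 4-methylpyridin-2-yl in place of 5-methylpyridin-2-yl on an oxygen on an aromatic ring. The two share the same atoms, joined differently, so nothing is added or taken away. Among the measured compounds shown here, no measured step compares two arrangements of the same methylpyridinyl group. For the measured compounds named here, the one step on record, a number 0.50 log units higher from compound 1 to compound 2 (beyond the scatter), concerns adding a methyl rather than moving it, so it bears only loosely on this change. For that reason the step from compound 2 to compound 3 in this assay is expected to be about no change at the digits printed from compound 2 to compound 3 (within the scatter), that is, nothing beyond the scatter. Compound 3 is thus estimated at 0.9, with a range from 0.6 to 1.2.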

Compound 3, distribution coefficient: 0.8
Compound 3: middle estimate off by 0.10 log units, on the high side; low and high end bracket the measured number.
By their numbers in this assay, from the lowest: compound 1; then compounds 3 and 2 (each within the scatter of the next).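

Moving the methyl group, with 4-methylpyridin-2-yl in place of 5-methylpyridin-2-yl on the oxygen, gives a number 0.10 log units lower from compound 2 to compound 3 (within the scatter) in this assay, so the two arrangements cannot be told apart on this read-out. Methyl in place of hydrogen on an aromatic carbon has now been seen at two different spots on the pyridine ring, with a number 0.50 log units higher from compound 1 to compound 2 (beyond the scatter) and a number 0.40 log units higher from compound 1 to compound 3 (beyond the scatter), so among these three compounds having the methyl matters more than where it sits. No measurement at hand explains this result.

The compounds shown leave open whether this holds only for methyl. An ethyl or methoxy group at either of these spots could follow the same pattern or break it.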